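Series notes: from compound 3 to compound 4

This account rests on a few compounds, and the source may have more. Where it says the series, first, only, none or still open, it means among the compounds named here.

Measured so far in a functional assay on NCI-H460 cells (Homo sapiens) for inhibition, read by MTT assay, with a stated time of 24 h, tested at 10 ug/mL; on this read-out lower numbers stand for less inhibition of growth and higher numbers for more inhibition of growth at the one concentration tested
compound 1 `CC(=O)SCCC(CCCCC(=O)O)SC(C)=O` gives 6.04%
compound 2 `O=C(CCCCC1CCSS1)Nc1ccc(Cl)cn1` gives 33.7%
compound 3 `O=C(CCCCC(CCSC(=O)c1ccccc1)SC(=O)c1ccccc1)Nc1ccccc1` gives 11.4%

Compound 3 sits within the scatter of compound 1 and lies lower than compound 2 by a gap beyond the scatter. Compound 4 `O=C(CCCCC(CCSC(=O)c1ccccc1)SC(=O)c1ccccc1)Nc1ccc(Cl)cc1` is not yet measured. It has chloro in place of hydrogen on an aromatic carbon, para to a large group, taking phenyl to 4-chlorophenyl: chloro in place of hydrogen on an aromatic carbon is the whole change. Going by the values given here, compound 2 also carries a chloro group, but it differs from compound 3 in more than one place, so the data hold no measured step for this change. In this assay a small upward move is expected, none beyond the scatter, and a number 2.6 percentage points higher from compound 3 to compound 4 (within the scatter) is the estimated step. This expectation starts from compound 3 at 11.4% as the closest measured structure. The expected value for compound 4 is 14% in an estimated range from 5% to 28% for repeated measurements.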

Compound 4, percent growth inhibition at one concentration: 12.6%
The estimate for compound 4 lay 1.4 percentage points above the measured number, within the range that was stated.
By their numbers in this assay, from the lowest: compounds 1, 3 and 4 (each within the scatter of the next); then compound 2.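

In this assay, going by these compounds alone, a number 1.2 percentage points higher from compound 3 to compound 4 (within the scatter) is the first step that isolates a single change. At this one concentration, chloro in place of hydrogen on an aromatic carbon, para to a large group, gives no readable shift in growth inhibition, so taking phenyl to 4-chlorophenyl leaves the read-out unresolved from the hydrogen parent. No supporting data bear on the origin of this result.

Open, going by these compounds, is whether methoxy, bromo or a dimethylamino group on the same aromatic carbon would give a step beyond the scatter, or whether chloro would behave the same way elsewhere on that ring. Also open, on these data alone, is how a longer chain between the amide carbonyl and the sulfur-bearing carbon would read here.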